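Hydroxy in Place of Benzyloxycarbonyl: What Compound 4 May Give

A few compounds are considered here, and "the series" means these few. Any claim that something is new, unique, unknown or untested is made for them only; others in the source may bear on it.

Compound 1, `O=C(CN(c1nc(Cl)nc2[nH]cnc12)C1CC1)N[C@@H](CC(=O)OCc1ccccc1)C(=O)OCc1ccccc1`: 6.68%
Compound 2, `O=C(CN(c1ncnc2c1ncn2C1CCCCO1)C1CC1)N[C@@H](CCC(=O)OCc1ccccc1)C(=O)OCc1ccccc1`: 14.1%
Compound 3, `CC(C)C[C@H](NC(=O)CN(c1ncnc2c1ncn2C1CCCCO1)C1CC1)C(=O)OCc1ccccc1`: 6.47%

Of the compounds shown here, three have been tested in a functional assay on the whole organism (Tail, strain ICR) with Mus musculus as the target, in the tail flick test, with a stated time of 150 min, at a dose of 25 umol/kg by the oral route; a lower number here means a weaker effect, a higher number a stronger effect of the compound at the dose given. Compound 1 gives 6.68%, the second highest of the three numbers; compound 3 lies nearest to it and compound 2 furthest, yet both gaps fall within the scatter, so the three compounds cannot be told apart on these data.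

Compound 4 `O=C(CN(c1nc(Cl)nc2[nH]cnc12)C1CC1)N[C@@H](CO)C(=O)OCc1ccccc1` has not yet been measured. It differs from compound 1 in one place: hydroxy in place of benzyloxycarbonyl on a saturated chain carbon, two bonds along the chain from an amide-type nitrogen and a carbonyl carbon. Within the data shown here, one measured step bears on this change, a number 7.6 percentage points lower from compound 2 to compound 3 (within the scatter), in which isopropyl replaced (benzyloxycarbonyl)methyl on the same kind of saturated chain carbon. That step lay within the scatter. The parallel is not exact: compound 4 carries a hydroxy rather than isopropyl, and the core of compound 1 is not the core of compounds 2 and 3. Among the measured compounds shown here, still, the one relevant precedent shows that losing the benzyloxycarbonyl from this position left the read-out essentially unchanged, so no step beyond the scatter is expected here either.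

Compound 4 is therefore estimated to give 6%, with a range from 0% to 15%. This expectation corresponds to a step of a number 0.7 percentage points lower from compound 1 to compound 4 (within the scatter), within the scatter.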

Compound 4, a percentage reported as activity, at one dose (the size of the read-out at that dose, not a potency): 27.9%
Compound 4: middle estimate off by 21.9 percentage points, on the low side, outside the stated range (above it).
By their numbers in this assay, from the lowest: compounds 3, 1 and 2 (each within the scatter of the next); then compound 4.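

In this assay the exchange of benzyloxycarbonyl for hydroxy gives a number 21.2 percentage points higher from compound 1 to compound 4 (beyond the scatter) and so shows that a change on this saturated chain carbon, two bonds along the chain from an amide-type nitrogen and a carbonyl carbon, can move the read-out beyond the scatter. Among these compounds, the only earlier step on this kind of carbon, in which isopropyl replaced (benzyloxycarbonyl)methyl on a different core, reads a number 7.6 percentage points lower from compound 2 to compound 3 (within the scatter) and did not show this, so losing the benzyloxycarbonyl does not always leave the read-out unchanged, and the outcome may depend on the entering group, the core or both. The data shown offer no explanation for the higher number of compound 4.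

Because the benzyloxycarbonyl leaves and the hydroxy enters in a single step, the compounds shown cannot separate the effect of the one from that of the other, and they leave open whether a carboxylic acid, an amine or a methoxy in the same place would give a similar number. From the compounds shown here alone, it also remains open whether a longer chain carrying the hydroxy, or the same exchange on the core of compound 2, would keep the gain.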